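A few compounds are considered here, and "the series" means these few. Any claim that something is new, unique, unknown or untested is made for them only; others in the source may bear on it.

Measured so far in a functional assay on the whole organism for inhibition, with Lemna aequinoctialis as the target, tested at 100 ug/mL; on this read-out lower numbers stand for less inhibition of growth and higher numbers for more inhibition of growth at the one concentration tested:
compound 1, `CCCCCCNC(=S)N/N=C1\C(=O)Nc2ccc([N+](=O)[O-])cc21`, 35%
compound 2, `Cc1ccc(NC(=S)N/N=C2\C(=O)Nc3ccc([N+](=O)[O-])cc32)cc1`, 20%
compound 3, `O=C1Nc2ccc([N+](=O)[O-])cc2/C1=N/NC(=S)Nc1ccccc1C(F)(F)F`, 15%

Compound 2 stands second highest of these three numbers: compound 3 lies within the scatter of it, and the step of a number 15 percentage points lower from compound 1 to compound 2 (beyond the scatter) is the only one beyond the scatter. Compound 4, `O=C1Nc2ccc([N+](=O)[O-])cc2/C1=N/NC(=S)Nc1ccc(Br)cc1`, differs from compound 2 by bromo in place of methyl on an aromatic carbon. Among the compounds with values here, no measured step exchanges one group for another at this place; the one step, a number 15 percentage points lower from compound 1 to compound 2 (beyond the scatter), swaps a hexyl chain for the whole 4-methylphenyl ring, which bears little on it. Compound 3, with a different group on that ring, sits within the scatter of compound 2. A step of no change at the digits printed from compound 2 to compound 4 (within the scatter) is therefore expected, none beyond the scatter. Compound 4 is estimated at 20%, between 5% and 40%.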

Compound 4, percent growth inhibition at one concentration: 15%
Compound 4: middle estimate off by 5 percentage points, on the high side, within the range that was stated.
By their numbers in this assay, from the lowest: compounds 3, 4 and 2 (each within the scatter of the next); then compound 1.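

In this assay, within the data shown here, this is the first direct exchange at this place on the aromatic ring, and it gives a number 5 percentage points lower from compound 2 to compound 4 (within the scatter), so methyl and bromo cannot be told apart here. A second aromatic ring in place of hexyl gives a number 20 percentage points lower from compound 1 to compound 4 (beyond the scatter), the same direction as a number 15 percentage points lower from compound 1 to compound 2 (beyond the scatter). Nothing available explains either result. Going by these compounds, whether an amine or a carboxylic acid at this same place would shift growth inhibition remains open. So does the effect of a chain longer than hexyl on the amide-type nitrogen.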